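Series notes: benzylamine replacements on the shared core

A few compounds are considered here, and "the series" means these few. Any claim that something is new, unique, unknown or untested is made for them only; others in the source may bear on it.

Measured so far:
- compound 1, `Nc1cccc(CNc2cc(C(F)(F)F)cc3[nH]ncc23)c1`: 24%
- compound 2, `O=[N+]([O-])c1ccc(CNc2cc(C(F)(F)F)cc3[nH]ncc23)cc1`: 52%
- compound 3, `O=[N+]([O-])c1cccc(CNc2cc(C(F)(F)F)cc3[nH]ncc23)c1`: 45%

In an assay for inhibition of Indoleamine 2,3-dioxygenase 1 (Homo sapiens), with stated times of 10 min and 60 min, tested at 10 uM (on this read-out lower numbers stand for a weaker effect and higher numbers for a stronger effect at the one concentration tested), compound 1 gives 24% and stands lowest of the three, with compound 3 nearest at 45% and compound 2 furthest at 52%. Within the data shown here, the one measured step of a single change is a number 21 percentage points higher from compound 1 to compound 3 (beyond the scatter), a modest gain within the aromatic ring that stays in place.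

Compound 4, `FC(F)(F)c1cc(NC[C@H]2CCCCN2)c2cn[nH]c2c1`, is not yet measured. It differs from compound 1 as follows: piperidin-2-yl in place of 3-aminophenyl on a saturated chain carbon bound to a nitrogen on an aromatic ring. Among the measured compounds shown here, the whole aromatic ring is exchanged for a saturated ring, so the step from compound 1 to compound 3, which only swaps one substituent on that ring, does not bear on it directly; no measured pair tells what such an exchange does in this assay. With no guide in either direction, the expectation for compound 4 is a step of about a number 1 percentage points higher from compound 1 to compound 4 (within the scatter), that is, none beyond the scatter, with wide uncertainty. Compound 4 is therefore estimated at 25%, in the range 5% to 55%.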

Compound 4, a percentage reported as inhibition, at one concentration (the size of the read-out at that concentration, not a potency): 19%
The estimate for compound 4 lay 6 percentage points above the measured number; measured number inside the range.
By their numbers in this assay, from the lowest: compounds 4 and 1 (each within the scatter of the next); then compounds 3 and 2 (each within the scatter of the next).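

In this assay, the step is a number 5 percentage points lower from compound 1 to compound 4 (within the scatter), so piperidin-2-yl and 3-aminophenyl cannot be told apart at this position on a saturated chain carbon bound to a nitrogen on an aromatic ring. Unlike the earlier step, which swapped only a substituent on a retained aromatic ring, this one exchanges the whole ring, and an aromatic ring at this place is not needed to keep a number of this size. Nothing measured here explains why the two groups read alike.

Still open, on these data alone, is whether the opposite configuration at the defined stereocentre of piperidin-2-yl would read the same. As far as these compounds go, it is also open whether a piperidin-3-yl, a morpholin-2-yl or a nitro group on a saturated ring would move the number beyond the scatter.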